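This account rests on a few compounds, and the source may have more. Where it says the series, first, only, none or still open, it means among the compounds named here.

Compounds measured so far:
compound 1 `CC(C)(C)c1cc(NC(=O)Nc2ccc(F)cc2)n(-c2ccccc2)n1`: -2.2 degrees C
compound 2 `CC(C)(C)c1cc(NC(=O)Nc2ccc(F)c(F)c2)n(-c2ccccc2)n1`: 2.2 degrees C
compound 3 `Cc1ccc(S(=O)(=O)NC(=O)Nc2cc(C(C)(C)C)nn2-c2ccccc2)cc1`: 0.2 degrees C

In an assay on isolated protein for inhibition of Ephrin type-A receptor 2 (Homo sapiens), read by thermal shift assay, tested at 10 uM (a lower number here means that the compound stabilises the target less, a higher number that the compound stabilises the target more against heat), compound 1 gives -2.2 degrees C, the lowest of the three numbers. Compound 3 stands nearest to it with 0.2 degrees C, and compound 2 furthest with 2.2 degrees C; both gaps lie beyond the scatter, so compound 1 is clearly the weakest stabiliser of the three.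

The step to compound 4 `COc1cccc(NC(=O)Nc2cc(C(C)(C)C)nn2-c2ccccc2)c1` is 3-methoxyphenyl in place of 4-fluorophenyl on an amide-type nitrogen. Among the compounds with values here, no measured step alters this ring in the same way. Within the data shown here, the only step on the same ring is a number 4.4 degrees C higher from compound 1 to compound 2 (beyond the scatter), which shows that a small change on this aryl group can move the reading a great deal. The values of compound 1 and compound 3 show that swapping the whole aryl group for another substituent also raises the number beyond the scatter. Both observations point upward from compound 1, but neither reproduces the methoxy-for-fluoro exchange, so the size remains uncertain.

Compound 4 is therefore expected to read somewhat higher than compound 1, a step of a number 1.9 degrees C higher from compound 1 to compound 4 (beyond the scatter), and its estimated value is -0.3 degrees C, in a range from -3 degrees C to 2.4 degrees C.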

Compound 4, shift of the target's melting temperature: 1.8 degrees C
Compound 4: the middle estimate sits 2.1 degrees C below what was measured, within the range that was stated.
By their numbers in this assay, from the lowest: compound 1; then compound 3; then compounds 4 and 2 (each within the scatter of the next).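

In this assay, replacing 4-fluorophenyl with 3-methoxyphenyl on the amide-type nitrogen gives a number 4.0 degrees C higher from compound 1 to compound 4 (beyond the scatter), so the rise seen at this aryl group does not depend on adding a second fluorine and also occurs with a group that contains no fluorine at all. Compound 4 and compound 2 stand level, with a number 0.40 degrees C lower from compound 2 to compound 4 (within the scatter), which means that 3-methoxyphenyl and 3,4-difluorophenyl cannot be told apart here even though they carry different substituents. Nothing in the data shown accounts for either rise from compound 1 or for this agreement between two different aryl groups.

The exchange from compound 1 to compound 4 removes the fluorine and introduces the methoxy group in a single step, so the compounds shown leave open how much of the rise belongs to losing the one and how much to gaining the other. They also leave open whether the level shared by compound 2 and compound 4 can be passed on this ring, for instance with an amine, a carboxylic acid or a longer alkoxy chain in place of the methoxy group.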